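The source may hold more compounds than are shown below. What is called first, only, known or untested is meant among the compounds shown, and "the series" means these compounds.

Compound 1 `Cc1occc1-c1nnc(SCC(=O)Nc2ccc(F)c(Cl)c2)n1Cc1ccco1`: 39.8 nM
Compound 2 `Cc1ccc(NC(=O)CSc2nnc(-c3ccoc3C)n2Cc2ccco2)cc1`: 39.8 nM
Compound 3 `Cc1occc1-c1nnc(SCC(=O)Nc2cccc(F)c2)n1Cc1ccco1`: 501 nM

All three compounds share one core and differ only in the aryl group on the amide-type nitrogen; all were tested in a functional assay on CHO cells for antagonist activity at Orexin receptor type 2 (Homo sapiens), read by FLIPR and calcium flux; a higher number here means a weaker inhibitor, a lower number a stronger inhibitor. Compound 3 stands at the highest number of the three, and both steps leading to it, a 13-fold higher number from compound 1 to compound 3 (1.10 log units; beyond the scatter) and a 13-fold higher number from compound 2 to compound 3 (1.10 log units; beyond the scatter), go the same way and by the same amount, so compound 3 is the weakest inhibitor of the set. Compound 1 and compound 2, by contrast, lie within the scatter of each other, as no change at the digits printed from compound 1 to compound 2 (within the scatter) shows.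

Compound 4 `CC(=O)c1ccc(NC(=O)CSc2nnc(-c3ccoc3C)n2Cc2ccco2)cc1` is still to be measured in this assay. It differs from compound 3 in one place: 4-acetylphenyl in place of 3-fluorophenyl on an amide-type nitrogen. Among the measured compounds shown here, no measured step shows the 4-acetylphenyl group itself; what bears on it is that the two measured steps onto the 3-fluorophenyl group, a 13-fold higher number from compound 1 to compound 3 (1.10 log units; beyond the scatter) and a 13-fold higher number from compound 2 to compound 3 (1.10 log units; beyond the scatter), were both large, so leaving the 3-fluorophenyl group is expected to lower the number, though with little certainty about how far. Compound 4 is therefore estimated at 100 nM, within 25 nM to 400 nM, an expected step of a 5.0-fold lower number from compound 3 to compound 4 (0.70 log units; beyond the scatter).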

Compound 4, inhibition constant: 31.6 nM
The estimate for compound 4 lay 3.2-fold (0.50 log units) above the measured number; the measured number falls inside the stated range.
By their numbers in this assay, from the lowest: compounds 4, 1 and 2 (each within the scatter of the next); then compound 3.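

In this assay, the 4-acetylphenyl group gives a 16-fold lower number from compound 3 to compound 4 (1.20 log units; beyond the scatter), so this position on the amide-type nitrogen accepts a larger group that carries a carbonyl and a hydrogen-bond acceptor, which none of the earlier aryl groups has. That acceptor leaves no mark beyond the scatter, since acetyl in place of methyl on an aromatic carbon gives a 1.3-fold lower number from compound 2 to compound 4 (0.10 log units; within the scatter), and the change from the halogenated ring gives a 1.3-fold lower number from compound 1 to compound 4 (0.10 log units; within the scatter); three quite different groups thus sit together, and among these four compounds the three with a group named at the 4-position stand apart from compound 3, whose 3-fluorophenyl has none there. Nothing given here explains why these groups behave alike or why compound 3 differs.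

The compounds shown leave open whether this tolerance extends to a 4-aminophenyl or 4-carboxyphenyl group, or to a longer chain such as 4-propionylphenyl, and where an unsubstituted phenyl would fall. They also leave open whether the same steps would hold with other groups on the shared core, which stays unchanged throughout.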